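Methyl added ortho to the thiazolidinedione-bearing methylene

The source may report more compounds than this note shows. Statements on the series, on what has been measured and on what is new or still open speak of the compounds shown alone.

Measured compounds:
compound 1 `Cc1cc(Oc2ncc(C(F)(F)F)cc2Cl)ccc1CC1SC(=O)NC1=O`: 10 nM
compound 2 `O=C1NC(=O)C(Cc2ccc(Cc3ccccc3)cc2)S1`: 9280 nM

In a functional assay for agonist activity at Free fatty acid receptor 1 (Homo sapiens), read by FLIPR, in the presence of a further agent that is not named here (on this read-out lower numbers stand for an effect already at smaller amounts and higher numbers for an effect only at larger amounts of compound), compound 1 gives 10 nM, the lower of the two numbers. Compound 2 gives 9280 nM, a gap beyond the scatter. Compound 3 `Cc1cc(Oc2ncc(C(F)(F)F)cc2Cl)cc(C)c1CC1SC(=O)NC1=O` is not yet measured; it differs from compound 1 thus: methyl in place of hydrogen on an aromatic carbon. Going by the values given here, no measured pair isolates this kind of change, so nothing shows its effect. A single methyl on an aromatic carbon is a small addition, and the step of a 1.5-fold higher number from compound 1 to compound 3 (0.18 log units; within the scatter) is expected to stay within the scatter, with no clear direction. Compound 3 is estimated at 15 nM, range 4 nM to 60 nM.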

Compound 3, half-maximal effective concentration: 5450 nM
Compound 3: middle estimate off by 360-fold (2.56 log units), on the low side; the measured number lies above the stated range.
By their numbers in this assay, from the lowest: compound 1; then compounds 3 and 2 (each within the scatter of the next).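

In this assay this aromatic carbon, ortho to the (2,4-dioxo-1,3-thiazolidin-5-yl)methyl group, proves highly sensitive: adding one methyl gives a 550-fold higher number from compound 1 to compound 3 (2.74 log units; beyond the scatter). A change of a single carbon can therefore decide activity in this series, and this position cannot be treated as open to substitution with methyl. No available evidence accounts for the step. As far as these compounds go, whether a fluorine atom or a methoxy group on the same carbon has a similar effect remains open, as does whether the methyl has this effect without the methyl group already on the ring.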